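Bromo in Place of Isopropyl on the Shared Core

The source may hold more compounds than are shown below. What is called first, only, known or untested is meant among the compounds shown, and "the series" means these compounds.

Of the compounds shown here, three have been measured in an assay on isolated protein for inhibition of serine/threonine-protein kinase TBK1 (Homo sapiens); a higher number here means a weaker inhibitor, a lower number a stronger inhibitor. Compound 1 `COCCC(=O)NCCCNc1nc(Nc2cccc(F)c2)ncc1Br` gives 60 nM. Compound 2 `CN1CCC(C(=O)NCCCNc2nc(Nc3cccc(F)c3)ncc2Br)CC1` gives 4300 nM. Going by the values given here, the one measured step between them is a 72-fold higher number from compound 1 to compound 2 (1.86 log units; beyond the scatter). Compound 3 `CC(C)c1cnc(Nc2cccc(F)c2)nc1NCCCNC(=O)C1CCC1` carries an isopropyl group on its core in place of the bromo of the first two, together with a cyclobutyl amide; its reading, > 1000 nM, is a limit of this assay and not a number. Compound 3 therefore stands at the limit of > 1000 nM in this assay, at which 1 of the 3 values shown sits, and how far beyond that limit it lies is not known.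

Compound 4 `O=C(NCCCNc1nc(Nc2cccc(F)c2)ncc1Br)C1CCC1` differs from compound 3 in one place: bromo in place of isopropyl on an aromatic carbon. Among the compounds with values here, no measured step pairs this change directly, since compound 1 and compound 2 both already carry bromo and differ from each other only at the amide. What the data show is that bromo compounds with a neutral amide, as in compound 1, sit well within the numeric range, while compound 3 with isopropyl gives only a limit.

Compound 4 is therefore expected to come in as a numeric value rather than a limit, at an estimated 200 nM, with a range from 40 nM to 1500 nM. The step of an at least 5.0-fold lower number from compound 3 to compound 4 (0.69 log units; beyond the scatter) is expected to move toward stronger inhibition.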

Compound 4, half-maximal inhibitory concentration: 2 nM
Compound 4: middle estimate off by 100-fold (2.00 log units), on the high side; the whole stated range lies above it.
By their numbers in this assay, from the lowest: compound 4; then compound 1; then compound 2.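

In this assay, bromo in place of isopropyl on an aromatic carbon, para to a (3-fluorophenyl)amino group, with the cyclobutyl amide held fixed, gives an at least 500-fold lower number from compound 3 to compound 4 (2.69 log units; beyond the scatter), which shows that the outcome at this position is decided by a change of a single group on the shared core. The reading of compound 3 is a limit and not a number: the limit of > 1000 nM in this assay, at which 1 of the 4 values shown sits. With bromo held in place, cyclobutyl on the carbonyl carbon gives a 30-fold lower number from compound 1 to compound 4 (1.48 log units; beyond the scatter) and also a 2200-fold lower number from compound 2 to compound 4 (3.33 log units; beyond the scatter), so the amide can move the number in the stronger direction as well, whereas the earlier step showed only a loss.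

The compounds shown leave open whether chloro, methyl or a plain hydrogen at this aromatic carbon would match bromo, and whether the same change would hold with the 2-methoxyethyl or 1-methylpiperidin-4-yl amide. They also leave open how a cyclopentyl group or a carboxylic acid on the carbonyl carbon would read in this assay, and how far compound 3 lies beyond its limit.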